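The compounds below may be only part of what the source reports. "The series", "measured", "known", "first", "only" and "open" are said of these compounds alone.

Measured in an assay on HEK293 cells for displacement of a labelled ligand from NPC1-like intracellular cholesterol transporter 1 (Homo sapiens); a higher number here means a weaker inhibitor, a lower number a stronger inhibitor:
compound 1 `CC(C)(C)OC(=O)NCCNC(=O)CN1CN(c2ccccc2)C2(CCN(C(=O)c3ccc(C(C)(C)C)cc3)CC2)C1=O`, 10900 nM
compound 2 `CC(C)(C)OC(=O)NCCNC(=O)CN1CN(c2ccccc2)C2(CCN(C(=O)c3ccc(C4CCCCC4)cc3)CC2)C1=O`, 5500 nM
compound 3 `CC1CCCN(C(=O)CN2CN(c3ccccc3)C3(CCN(C(=O)c4ccc(C(C)(C)C)cc4)CC3)C2=O)C1`, 12000 nM

Compound 2 gives the lowest number of the three; its nearest neighbour is compound 1, with a 2.0-fold lower number from compound 1 to compound 2 (0.30 log units; within the scatter), a gap within the scatter, while the gap to compound 3 lies beyond it. Compound 4 `CS(=O)(=O)NCCNC(=O)CN1CN(c2ccccc2)C2(CCN(C(=O)c3ccc(C4CCCCC4)cc3)CC2)C1=O` differs from compound 2 by methylsulfonyl in place of tert-butoxycarbonyl on an amine nitrogen. For the measured compounds named here, no measured step touches this group in the same way. Going by the values given here, the one change made on the amide side, a 1.1-fold higher number from compound 1 to compound 3 (0.04 log units; within the scatter), stayed within the scatter, which is the only hint that this side tolerates alteration. The expected step in this assay is therefore no change at the digits printed from compound 2 to compound 4 (within the scatter), none beyond the scatter. Compound 4 is estimated at 5500 nM, with a range of 2500 nM to 12000 nM.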

Compound 4, half-maximal inhibitory concentration: 2100 nM
Compound 4: middle estimate off by 2.6-fold (0.42 log units), on the high side; the measured number lies below the stated range.
By their numbers in this assay, from the lowest: compound 4; then compounds 2, 1 and 3 (each within the scatter of the next, the first and the last beyond it).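

On the amine nitrogen, tert-butoxycarbonyl is not required for activity in this assay, and the smaller methylsulfonyl gives a 2.6-fold lower number from compound 2 to compound 4 (0.42 log units; beyond the scatter). For the compounds shown here, this is the only step on this side of the molecule that lies beyond the scatter, whereas a 1.1-fold higher number from compound 1 to compound 3 (0.04 log units; within the scatter) stayed within it. Nothing available explains the lower number. Open, on these data alone, is whether a free amine, an acetyl group or a longer sulfonyl chain on this nitrogen would move the number further. Also open, as far as these compounds go, is whether methylsulfonyl gives a similar step with tert-butyl in place of cyclohexyl.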